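Swapping Trifluoromethyl for Methyl Beside a Retained Imidazole

A few compounds are considered here, and "the series" means these few. Any claim that something is new, unique, unknown or untested is made for them only; others in the source may bear on it.

Compound 1 `Cc1cn(-c2cc(NC(=O)c3ccc(C)c(Nc4nc(-c5cccnc5)cs4)c3)cc(C(F)(F)F)c2)cn1` is examined in a functional assay on KU812 cells (Homo sapiens) for antiproliferative activity (on this read-out higher numbers stand for weaker inhibition and lower numbers for stronger inhibition), where compound 1 gives 30 nM. That is the lowest of the three numbers shown, although compound 2 `Cc1ncn(-c2cc(NC(=O)c3ccc(C)c(Nc4nc(-c5cccnc5)cs4)c3)cc(C(F)(F)F)c2)n1`, which gives 38 nM, lies within the scatter of it: a 1.3-fold higher number from compound 1 to compound 2 (0.10 log units; within the scatter). Compound 3 `Cc1ccc(C(=O)Nc2cccc(C(F)(F)F)c2)cc1Nc1nc(-c2cccnc2)cs1` gives 1240 nM, and the steps to it are large: a 41-fold higher number from compound 1 to compound 3 (1.62 log units; beyond the scatter) and a 33-fold higher number from compound 2 to compound 3 (1.51 log units; beyond the scatter). Both large steps accompany removal of the 4-methyl-1H-imidazol-1-yl or 3-methyl-1H-1,2,4-triazol-1-yl group from the shared core; the group that changes on the way to compound 4 is a different one.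

Compound 4 `Cc1cc(NC(=O)c2ccc(C)c(Nc3nc(-c4cccnc4)cs3)c2)cc(-n2cnc(C)c2)c1` differs from compound 1 in one place: methyl in place of trifluoromethyl on an aromatic carbon. Within the data shown here, no measured pair differs at this position, so none of the three steps bears directly on the exchange. Compound 4 keeps the 4-methyl-1H-imidazol-1-yl group whose loss marked the large steps to compound 3. The expectation for compound 4 is therefore a number not far from that of compound 1, with a modest loss allowed for an exchange without precedent here: a 2.0-fold higher number from compound 1 to compound 4 (0.30 log units; within the scatter) is the step expected. Compound 4 is estimated at 60 nM, within a range from 20 nM to 250 nM.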

Compound 4, half-maximal inhibitory concentration: 871 nM
For compound 4 the middle estimate is 15-fold (1.16 log units) below the measured one; measured number outside the range, above it.
By their numbers in this assay, from the lowest: compounds 1 and 2 (each within the scatter of the next); then compounds 4 and 3 (each within the scatter of the next).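

In this assay, the exchange of trifluoromethyl for methyl proves to be far from neutral: the result is a 29-fold higher number from compound 1 to compound 4 (1.46 log units; beyond the scatter). Among these compounds, this position, which no earlier pair touched, therefore carries a large step of its own, and keeping the 4-methyl-1H-imidazol-1-yl group is not enough to hold the number close to that of compound 1, even though removing that group also gave a large step, a 41-fold higher number from compound 1 to compound 3 (1.62 log units; beyond the scatter). No supporting measurement bears on why the exchange costs so much, so the change in the number is all that can be stated.

The compounds shown leave open whether a chlorine atom, a nitrile or an ethyl group at this position would give a number closer to that of compound 1 or to that of compound 4. They also leave open whether the same exchange of trifluoromethyl for methyl would give a step of similar size in compound 2, which carries the 3-methyl-1H-1,2,4-triazol-1-yl group.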